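The compounds below may be only part of what the source reports. "The series", "measured", "known", "first", "only" and "open" are said of these compounds alone.

Among the compounds measured in an ADME assay on WI-38 cells (Homo sapiens) for cytotoxicity, read by MTT assay, with a stated time of 72 h (on this read-out higher numbers stand for weaker inhibition and lower numbers for stronger inhibition), compound 1 `CN(C)CCn1cnnc1-c1cc(Oc2ccc(NC(=O)Nc3ccc(Cl)c(C(F)(F)F)c3)cc2F)ccn1` gives 3760 nM, the lowest of the two numbers available. Compound 3 `CN(C)CCn1cnnc1-c1cc(Oc2ccc(NC(=O)Nc3ccc(Cl)cc3Cl)cc2F)ccn1`, which carries 2,4-dichlorophenyl on the amide-type nitrogen, gives 10400 nM in this assay, a step of a 2.8-fold higher number from compound 1 to compound 3 (0.44 log units; beyond the scatter). Compound 2 `CN(C)CCn1cnnc1-c1cc(Oc2ccc(NC(=O)Nc3ccc(F)c(F)c3)cc2F)ccn1`, with 3,4-difluorophenyl in that place, reaches only a limit of the assay, > 50000 nM, and not a number. This is the limit of > 50000 nM in this assay, at which 1 of the 3 values shown sits. The step of an at least 13-fold higher number from compound 1 to compound 2 (1.12 log units; beyond the scatter) is therefore known only as a bound, as is an at least 4.8-fold lower number from compound 2 to compound 3 (0.68 log units; beyond the scatter).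

Compound 4 `CCN(CC)CCn1cnnc1-c1cc(Oc2ccc(NC(=O)Nc3ccc(Cl)c(C(F)(F)F)c3)cc2F)ccn1` departs from compound 1 elsewhere: diethylamino in place of dimethylamino on a saturated chain carbon, two bonds along the chain from an aromatic nitrogen. None of the three measured steps touch this part of the molecule; all of them exchange the aryl group on the amide-type nitrogen, and the 2-(dimethylamino)ethyl chain is the same in compounds 1, 2 and 3. The measured steps, one modest and two known only as bounds, thus give no guide to the size or direction of any change in this assay when dimethylamino becomes diethylamino. In the absence of such a guide, the expected step is a 1.1-fold higher number from compound 1 to compound 4 (0.03 log units; within the scatter), within the scatter. Compound 4 is accordingly estimated at 4000 nM in this assay, with a range from 1800 nM to 9000 nM.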

Compound 4, half-maximal inhibitory concentration: 6730 nM
Compound 4: middle estimate off by 1.7-fold (0.23 log units), on the low side; measured number inside the range.
By their numbers in this assay, from the lowest: compounds 1, 4 and 3 (each within the scatter of the next, the first and the last beyond it). At a limit, above all of these: compound 2.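

In this assay the only change shown on this chain, diethylamino in place of dimethylamino, is a 1.8-fold higher number from compound 1 to compound 4 (0.25 log units; within the scatter) and so does not separate the two compounds. This position, on a saturated chain carbon, two bonds along the chain from an aromatic nitrogen, therefore differs from the aryl group on the amide-type nitrogen, where exchanges give a 2.8-fold higher number from compound 1 to compound 3 (0.44 log units; beyond the scatter) and an at least 13-fold higher number from compound 1 to compound 2 (1.12 log units; beyond the scatter) and both lie beyond the scatter, although the second is known only as a bound. Nothing shown here bears on what lies behind the size of the new step.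

The compounds shown leave open whether diethylamino would give a similar result with 2,4-dichlorophenyl or 3,4-difluorophenyl on the amide-type nitrogen, since this change is seen only with 4-chloro-3-(trifluoromethyl)phenyl. They also leave open how this read-out would respond to a larger change at the chain end or in its length, such as a morpholine or pyrrolidine ring in place of dimethylamino, a primary amine, or a longer chain carrying the same amine.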